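This account rests on a few compounds, and the source may have more. Where it says the series, first, only, none or still open, it means among the compounds named here.

Measured so far:
compound 1, `Cc1cc(Nc2cc(N3CCN(C)CC3)nc(Nc3cccc([N+](=O)[O-])c3)n2)n[nH]1`, gives 166 nM in a functional assay on A-431 cells (Homo sapiens) for antiproliferative activity, read by CCK-8 assay, with a stated time of 72 h; a lower number here means a stronger inhibitor, a higher number a weaker inhibitor
compound 2, `Cc1cc(Nc2cc(N3CCN(C)CC3)nc(Nc3ccc(C#N)cc3)n2)n[nH]1`, gives 140 nM in this assay

Going by the values given here, compound 2 has the lowest of the two numbers, but the only step that separates it from compound 1 is a 1.2-fold lower number from compound 1 to compound 2 (0.07 log units; within the scatter), so the two compounds are not truly distinguished. Compound 3, `Cc1cc(Nc2cc(N3CCN(C)CC3)nc(Nc3ccc(S(N)(=O)=O)cc3)n2)n[nH]1`, keeps the shared core and differs from compound 2 by sulfamoyl in place of cyano on an aromatic carbon. Among the compounds with values here, no measured step involves a sulfamoyl group, so the one step at hand bears on it only loosely: swapping one small group on the outer phenyl ring for another left the number essentially unchanged. The step expected in this assay is therefore a 1.2-fold higher number from compound 2 to compound 3 (0.08 log units; within the scatter), with no clear direction beyond the scatter. Compound 3 is estimated at 170 nM, in a range from 60 nM to 500 nM.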

Compound 3, half-maximal inhibitory concentration: 2760 nM
For compound 3 the middle estimate is 16-fold (1.21 log units) below the measured one; measured number above the stated range.
By their numbers in this assay, from the lowest: compounds 2 and 1 (each within the scatter of the next); then compound 3.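

The outer phenyl ring does not take every small group alike: this assay shows a 20-fold higher number from compound 2 to compound 3 (1.29 log units; beyond the scatter) for this change on the aromatic carbon, and a 17-fold higher number from compound 1 to compound 3 (1.22 log units; beyond the scatter) when the 3-nitrophenyl group is the starting point. Going by these compounds alone, the earlier pair, with nitro and cyano groups, stood within the scatter of each other, so its flat result does not extend to sulfamoyl, the first group here to shift the number clearly. The information at hand gives no explanation for this rise.

The compounds shown do not settle whether the whole sulfamoyl group matters or only the hydrogens on its nitrogen. A methyl sulfone or a carboxylic acid on the same carbon would be informative, but neither is among the compounds shown.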